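The source may report more compounds than this note shows. Statements on the series, on what has been measured and on what is new or still open speak of the compounds shown alone.

Measured compounds:
- compound 1, `CC#CC(CC(=O)O)c1ccc(OCc2ccn3cc(-c4ccccc4)nc3c2)cc1`: 1260 nM
- compound 2, `CC#CC(CC(=O)O)c1ccc(OCc2ccc3nc(-c4ccccc4F)cn3c2)cc1`: 583 nM

In an assay on isolated protein for agonist activity at Free fatty acid receptor 1 (Homo sapiens) (on this read-out lower numbers stand for an effect already at smaller amounts and higher numbers for an effect only at larger amounts of compound), compound 1 gives 1260 nM, the highest of the two numbers recorded. Compound 2 gives 583 nM, a lower number, and the gap between the two lies beyond the usual scatter; compound 2 differs from compound 1 in more than one place, so no single step can be read from that pair.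

Compound 3, `CC#CC(CC(=O)O)c1ccc(OCc2ccn3cc(-c4ccc(F)cc4)nc3c2)cc1`, remains to be measured in this assay. It departs from compound 1 by one change: fluoro in place of hydrogen on an aromatic carbon. The place is an aromatic carbon of a six-membered aromatic ring of carbon only, para to a large group; read one bond further out, phenyl becomes 4-fluorophenyl.

Nothing measured here shows what a fluoro in place of hydrogen at this place does on its own. The expected step from compound 1 to compound 3 is a 1.3-fold lower number from compound 1 to compound 3 (0.12 log units; within the scatter), small and within the scatter in either direction. Compound 3 is therefore estimated at 950 nM, with a range of 400 nM to 2300 nM.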

Compound 3, half-maximal effective concentration: 783 nM
Compound 3: middle estimate off by 1.2-fold (0.08 log units), on the high side; the range from low to high includes it.
By their numbers in this assay, from the lowest: compounds 2, 3 and 1 (each within the scatter of the next, the first and the last beyond it).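

Fluoro in place of hydrogen at this aromatic carbon, para to a large group, gives the first single-change read-out in the series: in this assay, it amounts to a 1.6-fold lower number from compound 1 to compound 3 (0.21 log units; within the scatter). A step of this size does not separate 4-fluorophenyl from phenyl at this place, so the replacement can be made here without a change beyond the scatter. No measurement at hand accounts for the size of this step.

Steps involving compound 2 cannot be read, as it differs from compound 1 and compound 3 in more than one place, so the effect of fluoro elsewhere on the phenyl remains open. Also open, as far as these compounds go, is how this same place responds to a larger or differently built group, such as chloro, methoxy, an amine or a carboxylic acid.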